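The source may hold more compounds than are shown below. What is called first, only, known or untested is meant among the compounds shown, and "the series" means these compounds.

Compound 3 `CC(=O)Oc1ccccc1C(=O)O[C@H]1CO[C@H]2[C@@H]1OC[C@H]2OC(=O)c1ccccc1C` gives the lowest of the three numbers in an ADME assay on a cell-free system (plasma, Homo sapiens) for metabolic stability, with Plasma (Rattus norvegicus) as the target, read by HPLC, at pH 7.4 (on this read-out higher numbers stand for a longer-lived compound and lower numbers for a shorter-lived compound), standing at 0.035 h. Compound 1 `CC(=O)Oc1ccccc1C(=O)O[C@H]1CO[C@H]2[C@@H]1OC[C@H]2OC(=O)c1ccccc1O` gives 0.0825 h and compound 2 `CC(=O)Oc1ccccc1C(=O)O[C@H]1CO[C@H]2[C@@H]1OC[C@H]2OC(=O)c1ccnn1C` gives 0.0963 h; the step of a 1.2-fold higher number from compound 1 to compound 2 (0.07 log units; within the scatter) lies within the scatter, whereas a 2.4-fold lower number from compound 1 to compound 3 (0.37 log units; beyond the scatter) and a 2.8-fold lower number from compound 2 to compound 3 (0.44 log units; beyond the scatter) are modest downward steps. Compound 4 `CC(=O)Oc1ccccc1C(=O)O[C@H]1CO[C@H]2[C@@H]1OC[C@H]2OC(=O)c1ccc(-c2ccccc2)cc1` differs from compound 3 by 4-phenylphenyl in place of 2-methylphenyl on a carbonyl carbon. Among the measured compounds shown here, of the measured steps, a 2.8-fold lower number from compound 2 to compound 3 (0.44 log units; beyond the scatter) is the one that also exchanges the aryl group on the carbonyl carbon, and a 2.4-fold lower number from compound 1 to compound 3 (0.37 log units; beyond the scatter) places compound 3 beneath both companions. The step expected here is a 2.0-fold higher number from compound 3 to compound 4 (0.30 log units; within the scatter), a modest rise back toward the level of compound 1. Compound 4 is therefore estimated to give 0.07 h, within a range from 0.03 h to 0.16 h.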

Compound 4, half-life: > 0.333 h
Compound 4 was reported as a limit; the forecaster's own chance of this, stated with the estimate: 5%; at least 4.7-fold (0.67 log units) between middle value and limit.
By their numbers in this assay, from the lowest: compound 3; then compounds 1 and 2 (each within the scatter of the next). At a limit, above all of these: compound 4.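

In this assay, compound 4 is reported only as a limit, > 0.333 h. Exchanging the group on this carbonyl carbon, which had given modest steps at most, now gives an at least 9.5-fold higher number from compound 3 to compound 4 (0.97 log units; beyond the scatter), and the same change also gives an at least 3.4-fold higher number from compound 2 to compound 4 (0.53 log units; beyond the scatter) and an at least 4.0-fold higher number from compound 1 to compound 4 (0.60 log units; beyond the scatter). Of the four, only compound 4, carrying 4-phenylphenyl with its two aromatic rings, stands at the limit.

On these data alone, how much of the step rests on the second ring stays open, as does the outcome with a plain phenyl or an aminophenyl group in this place.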